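The source may report more compounds than this note shows. Statements on the series, on what has been measured and on what is new or still open speak of the compounds shown alone.

Compound 1 `CCN(Cc1ccccc1)C(=O)C1CCN(S(=O)(=O)c2ccccc2OC)CC1` belongs to a small set of compounds that share one core and differ only in the group attached to the sulfonyl sulfur. The measure of interest is a functional assay on CHO cells for positive allosteric modulation of muscarinic acetylcholine receptor M5 (Homo sapiens), read by calcium flux; a lower number here means a smaller maximal response, a higher number a larger maximal response. In this assay compound 1 gives "not determined" (no result reported), so there is no single number on which compound 1 can be placed. Compound 3 `CCN(Cc1ccccc1)C(=O)C1CCN(S(=O)(=O)c2cccnc2)CC1` stands the same way: in this assay compound 3 gives "not determined" (no result reported). Among the compounds with values here, the only number in the set comes from compound 2 `CCN(Cc1ccccc1)C(=O)C1CCN(S(=O)(=O)c2cccc3c2OCCO3)CC1`, which in this assay gives 53%.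

Compound 4 `CCN(Cc1ccccc1)C(=O)C1CCN(S(=O)(=O)c2ccc3cn[nH]c3c2)CC1` has not yet been measured. It differs from compound 1 in one place: 1H-indazol-6-yl in place of 2-methoxyphenyl on a sulfonyl sulfur. Within the data shown here, with no measured step between any two compounds of this set, there is no ground for expecting a step in this assay in one direction rather than the other beyond the usual scatter, and the expectation for compound 4 rests on the one number from compound 2. Compound 4 is therefore estimated to give about 55%, in a range from 30% to 85%.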

Compound 4, largest response reached (reported as percent of maximum), in percent of the reference or control that the assay uses: 86%
Compound 4: middle estimate off by 31 percentage points, on the low side; measured number above the stated range.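

In this assay, within the data shown here, the group on the sulfonyl sulfur can clearly shift the maximal response: with the rest of the molecule unchanged, 1H-indazol-6-yl in place of 2,3-dihydro-1,4-benzodioxin-5-yl gives a number 33 percentage points higher from compound 2 to compound 4 (beyond the scatter) as the first readable step in this set. Compound 1 and compound 3 have no number, so steps involving them cannot be read. Nothing given here accounts for the size of this step.

Going by these compounds, it remains open whether the ring nitrogens of 1H-indazol-6-yl are needed, which a 1H-indol-6-yl or 2-naphthyl group on the sulfonyl sulfur could help to settle. On these data alone, what a propyl chain in place of the ethyl group of the shared core would do also remains open.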